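The source may hold more compounds than are shown below. What is called first, only, known or untested is meant among the compounds shown, and "the series" means these compounds.

Compound 1, with the structure `COc1ccc(-c2cnc(NC(=O)CCc3ccccc3)n2C)cc1`, gives > 100000 nM in a toxicity assay on THP-1 cells (Homo sapiens) for inhibition; a higher number here means that more compound is tolerated, a lower number that less compound is tolerated; that is a limit of the assay, not a number.
Compound 2, with the structure `COc1ccc(-c2cnc(NC(=O)c3ccco3)n2C)cc1`, gives > 100000 nM in this assay; again only a limit.
Compound 3, with the structure `COc1ccc(-c2cnc(NC(=O)c3ccc(O)cc3)n2C)cc1`, gives > 100000 nM in this assay; once more a limit.

Compound 3 therefore stands only at a limit, with no measured number, and the two other values stand at the same limit, as shown by the limit of > 100000 nM in this assay, at which 3 of the 3 values shown sit. Compound 4, with the structure `COc1ccc(-c2cnc(NC(=O)c3cccc(C)c3)n2C)cc1`, has not yet been measured. It differs from compound 3 at one place: 3-methylphenyl in place of 4-hydroxyphenyl on a carbonyl carbon.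

The measured steps that bear on this are the exchanges of the group on the carbonyl carbon: a step that the two limits leave unreadable from compound 1 to compound 3, a step that the two limits leave unreadable from compound 2 to compound 3 and a step that the two limits leave unreadable from compound 1 to compound 2. None of them could be read in size, because of the limit of > 100000 nM in this assay, at which 3 of the 3 values shown sit. No step beyond the scatter can be foreseen in this assay, in either direction. Compound 4 is therefore expected to sit at about 100000 nM, within 50000 nM to 300000 nM, which means an expected step of a number no higher from compound 3 to compound 4 (the limit leaves the size open).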

Compound 4, half-maximal cytotoxic concentration: > 100000 nM
Compound 4 gave a limit, no number (the forecaster's own chance of this, stated with the estimate: 85%); the middle value sits exactly at the limit.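

Going by these compounds alone, compound 4 stands at a limit of the assay, not a number, as do compound 1, compound 2 and compound 3, so no new step to compound 4 can be read: (the limit of > 100000 nM in this assay, at which 4 of the 4 values shown sit). The compounds shown leave open what concentration of any of them would harm these cells, and whether the group on the carbonyl carbon changes it.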